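Adding a methoxy to the anilino amide of compound 3

This account rests on a few compounds, and the source may have more. Where it says the series, first, only, none or still open, it means among the compounds named here.

In a functional assay on HL-60 cells (Homo sapiens) for antiproliferative activity, read by MTT assay, with a stated time of 24 h (a higher number here means a weaker inhibitor, a lower number a stronger inhibitor), compound 1 (`CCCCc1oc2ccccc2c1C(=O)c1ccc(OCC(=O)NC(C)C)cc1`) gives 360 nM. Compound 2 (`CCCCc1oc2ccccc2c1C(=O)c1ccc(OCC(=O)N2CCCC2)cc1`) reads > 50000 nM, which is a limit of the assay and not a number. Compound 3 (`CCCCc1oc2ccccc2c1C(=O)c1ccc(OCC(=O)Nc2ccccc2)cc1`) reads > 50000 nM, which is also a limit. Compound 3 therefore has no exact value and sits at the limit of > 50000 nM in this assay, at which 2 of the 3 values shown sit.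

Compound 4 (`CCCCc1oc2ccccc2c1C(=O)c1ccc(OCC(=O)Nc2cccc(OC)c2)cc1`) differs from compound 3 in one place: methoxy in place of hydrogen on an aromatic carbon. In plainer terms, phenyl becomes 3-methoxyphenyl on the amide nitrogen.

Among the compounds with values here, two measured steps bear on this change, and both are large. Replacing the isopropylamino group with pyrrolidin-1-yl gave an at least 130-fold higher number from compound 1 to compound 2 (2.14 log units; beyond the scatter). Replacing isopropyl with phenyl on the amide nitrogen gave an at least 130-fold higher number from compound 1 to compound 3 (2.14 log units; beyond the scatter). Both steps alter the group on the amide, and neither shows what a methoxy on the phenyl ring does, so the evidence for this change is indirect.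

Compound 4 keeps the phenyl ring behind the step of an at least 130-fold higher number from compound 1 to compound 3 (2.14 log units; beyond the scatter), so it is expected to stay weak, with no clear recovery towards compound 1. The expected change is a number no higher from compound 3 to compound 4 (the limit leaves the size open). For compound 4 the estimated value is 50000 nM, with an expected range from 12000 nM to 100000 nM.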

Compound 4, half-maximal inhibitory concentration: > 50000 nM
Compound 4: a limit, no number; the forecaster's own chance of this, stated with the estimate: 70%; the middle value sits exactly at the limit.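

In this assay compound 4 reads > 50000 nM, which is a limit of the assay and not a number. This is the first compound shown with a group on the phenyl ring of the anilino amide, and the methoxy brings no measurable activity back: 3-methoxyphenyl in place of isopropyl on the amide nitrogen gives an at least 130-fold higher number from compound 1 to compound 4 (2.14 log units; beyond the scatter). The steps to compound 4 from compound 2 and from compound 3 cannot be read, as each joins two limits, and compound 4 now stands with those two compounds: the limit of > 50000 nM in this assay, at which 3 of the 4 values shown sit.

The compounds shown leave open whether the methoxy changes anything at all beyond the limit, as compound 3 and compound 4 could still differ there. They also leave open whether a carboxylic acid or an amine on the phenyl ring, or an ethyl or tert-butyl group in place of the ring on the amide nitrogen, would give a measurable number close to that of compound 1.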